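Formyl replacement on the shared core

A few compounds are considered here, and "the series" means these few. Any claim that something is new, unique, unknown or untested is made for them only; others in the source may bear on it.

Of the compounds shown here, three have been read in a functional assay on HepG2 cells (Homo sapiens) for cytotoxicity, with a stated time of 72 h (on this read-out lower numbers stand for an effect already at smaller amounts and higher numbers for an effect only at larger amounts of compound), so far. Compound 1 (`C=C[C@@](C)(/C=C/c1ccc(O)cc1)CC/C=C/C(=O)OCc1ccccc1`) gives > 52000 nM, a limit of the assay and not a number. Compound 2 (`C=C[C@@](C)(/C=C/c1ccc(O)cc1)CC/C=C(C)/C=C/C(=O)OCc1ccccc1`) gives > 52000 nM, again a limit. Compound 3 (`C=C[C@@](C)(/C=C/c1ccc(O)c(C=O)c1)CCC=C(C)C`) gives > 52000 nM, also a limit. Compound 3 therefore has no number of its own and stands at the limit of > 52000 nM in this assay, at which 3 of the 3 values shown sit. Among the measured compounds shown here, no measured pair differs in one place, so no measured step is available as a guide.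

Compound 4 (`C=C[C@@](C)(/C=C/c1ccc(O)c(/C=C(\C)C(=O)OCC)c1)CCC=C(C)C`) carries 2-(ethoxycarbonyl)prop-1-en-1-yl in place of formyl on an aromatic carbon, ortho to a hydroxy group (2-(ethoxycarbonyl)prop-1-en-1-yl in place of formyl on an aromatic carbon).

In this assay, no step beyond the scatter is expected, since the limit of compound 3 at > 52000 nM offers no number to move from, and only a move towards lower numbers could be detected. The estimated change is an at least 1.0-fold lower number from compound 3 to compound 4 (0.01 log units; that floor lies within the scatter). For compound 4 the expected value is 50000 nM, with an estimated range from 22000 nM to 90000 nM.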

Compound 4, half-maximal effective concentration: > 52000 nM
Compound 4: a limit, no number (the forecaster's own chance of this, stated with the estimate: 70%); middle value at least 1.0-fold (0.01 log units) from the limit.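

Compound 3 and compound 4 both sit at a limit of this assay, not at a number, so no step can be read between them: the limit of > 52000 nM in this assay, at which 4 of the 4 values shown sit.

The compounds shown leave open whether any change on the shared core gives a measurable value in this assay.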